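Swapping one five-membered ring for another on the amide

The source may hold more compounds than are shown below. What is called first, only, known or untested is meant among the compounds shown, and "the series" means these compounds.

Compound 2 `COc1cc(C(=O)NC2(C(=O)N[C@H](C)c3ccc(-n4nc(Cl)c5ccccc54)cc3F)CC2)on1` carries a 3-methoxy-1,2-oxazol-5-yl group on a carbonyl carbon. In an in vivo ADME assay on the whole organism (strain Sprague-Dawley) for metabolic stability, with Rattus norvegicus as the target (a lower number here means that the compound disappears faster, a higher number that the compound lasts longer), compound 2 gives 3.1 h. Its nearest measured relative is compound 1 `C[C@@H](NC(=O)C1(NC(=O)c2cncc(Br)c2)CC1)c1ccc(-n2nc(Cl)c3ccccc32)cc1F`, which instead carries 5-bromopyridin-3-yl on that carbonyl carbon; in this assay compound 1 gives 3.1 h, and the step of no change at the digits printed from compound 1 to compound 2 (within the scatter) shows that this exchange of rings left the half-life level. Compound 3 `COc1ncc(C(=O)NC2(C(=O)N[C@H](C)c3ccc(-n4nc(Cl)c5ccccc54)cc3F)CC2)s1` differs from compound 2 by 2-methoxy-1,3-thiazol-5-yl in place of 3-methoxy-1,2-oxazol-5-yl on a carbonyl carbon. Among the measured compounds shown here, the only measured step that bears on such a change, no change at the digits printed from compound 1 to compound 2 (within the scatter), was flat, so a further exchange of one small ring for another on a carbonyl carbon is expected to give no change at the digits printed from compound 2 to compound 3 (within the scatter), that is, no step beyond the scatter. Compound 3 is therefore expected to show a half-life near 3.1 h, most likely falling between 1.5 h and 6.5 h.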

Compound 3, half-life: 8.3 h
Estimate against measurement, compound 3: 2.7-fold (0.43 log units) below; measured number above the stated range.
By their numbers in this assay, from the lowest: compounds 1 and 2 (each within the scatter of the next); then compound 3.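

In this assay, this position on a carbonyl carbon proves not to be indifferent to the ring it carries: 2-methoxy-1,3-thiazol-5-yl in place of 3-methoxy-1,2-oxazol-5-yl gives a 2.7-fold higher number from compound 2 to compound 3 (0.43 log units; beyond the scatter) in the half-life. The two groups match in heavy atoms and in hydrogen-bond acceptors, so even an exchange that leaves those counts the same can move this read-out, although the earlier exchange of rings did not. Set against 5-bromopyridin-3-yl, the same group gives a 2.7-fold higher number from compound 1 to compound 3 (0.43 log units; beyond the scatter) as well, so compound 3 stands apart from both other compounds.

From the compounds shown here alone, whether the gain stays with the methoxy group removed or replaced, for instance by an amine or a methyl group on the same ring, remains open. Nothing given here explains why the half-life rose.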